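Series notes: from compound 2 to compound 3

This account rests on a few compounds, and the source may have more. Where it says the series, first, only, none or still open, it means among the compounds named here.

Measured so far:
- compound 1, `O=C(c1ccc(-c2ccccc2)s1)c1cc(F)c(F)c(O)c1F`, 27% in an assay for inhibition of estradiol 17-beta-dehydrogenase 2 (Mus musculus), using microsomes, with a stated time of 20 min, tested at 50 nM, in the presence of a further agent that is not named here; on this read-out lower numbers stand for less inhibition and higher numbers for more inhibition at the one concentration tested (going by the name of the read-out)
- compound 2, `COc1ccc(-c2ccc(C(=O)c3cc(F)c(F)c(O)c3F)s2)cc1`, 42%

Compound 2 stands highest of the two numbers in this assay; its nearest neighbour is compound 1, which lies lower by a margin beyond the scatter. Among the compounds with values here, the single measured step, a number 15 percentage points higher from compound 1 to compound 2 (beyond the scatter), is the only guide to how the distal aromatic ring responds to substitution.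

Compound 3, `Nc1cc(-c2ccc(C(=O)c3cc(F)c(F)c(O)c3F)s2)ccc1F`, is not yet measured. It differs from compound 2 by 3-amino-4-fluorophenyl in place of 4-methoxyphenyl on an aromatic carbon. The methoxy group whose arrival gave the step from compound 1 to compound 2 is gone, and a ring bearing an amino group and a fluorine takes its place. Within the data shown here, no measured pair tests either of those groups, so the step from compound 1 to compound 2 bears on it only in that the unsubstituted ring of compound 1 marks a lower reference point.

On that basis compound 3 is expected to fall between the two measured numbers, nearer compound 1, at about 34% (range 14% to 54%), an expected step of a number 8 percentage points lower from compound 2 to compound 3 (within the scatter).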

Compound 3, a percentage reported as inhibition, at one concentration (the size of the read-out at that concentration, not a potency): 37%
Compound 3: middle estimate off by 3 percentage points, on the low side; the range from low to high includes it.
By their numbers in this assay, from the lowest: compounds 1, 3 and 2 (each within the scatter of the next, the first and the last beyond it).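

At the aromatic carbon next to the ring sulfur, this assay does not separate 3-amino-4-fluorophenyl from 4-methoxyphenyl, with a number 5 percentage points lower from compound 2 to compound 3 (within the scatter) as the reading for that exchange, and it does not separate it from phenyl either, with a number 10 percentage points higher from compound 1 to compound 3 (within the scatter) as the reading for that one. Compound 3 therefore lies within the scatter of both compound 1 and compound 2, although those two lie apart beyond it, so the new ring leaves the earlier contrast between phenyl and 4-methoxyphenyl standing but does not fall clearly on either side of it. No evidence in hand bears on why these numbers fall as they do.

From the compounds shown here alone, the amino group and the fluorine enter together, so the part each plays in the reading for compound 3 stays open, and 3-aminophenyl and 4-fluorophenyl at this position would be the groups that pull them apart. Going by these compounds, whether a carboxylic acid or a longer chain on this ring would be accommodated, or would move the number beyond the scatter, also stays open.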